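This account rests on a few compounds, and the source may have more. Where it says the series, first, only, none or still open, it means among the compounds named here.

Measured in a functional assay on DU-145 cells (Homo sapiens) for inhibition, read by trypan blue exclusion, with a stated time of 96 h; on this read-out higher numbers stand for weaker inhibition of growth and lower numbers for stronger inhibition of growth:
- Compound 1 `COc1ccc(/C=C(/SCc2ccc(Cl)cc2)C(=O)c2ccc(Br)cc2)cc1`: 10000 nM
- Compound 2 `CN(C)c1ccc(/C=C(/SCc2ccc(Cl)cc2)C(=O)c2ccc(Cl)cc2)cc1`: > 100000 nM

Only compound 1 has a true number here. Compound 2 gives > 100000 nM, which is a limit of the assay and not a number.

Compound 3 `CN(C)c1ccc(/C=C(/SCc2ccc(Cl)cc2)C(=O)c2ccc(Br)cc2)cc1` is compound 2 with one small change: bromo in place of chloro on an aromatic carbon. Put simply, the 4-chlorophenyl becomes a 4-bromophenyl, with bromo in place of chloro on an aromatic carbon. Among the measured compounds shown here, no measured pair here isolates this swap, so its effect has not been seen directly. For such a small swap, no step beyond the scatter is expected in this assay, in either direction. Compound 3 shares its 4-bromophenyl with compound 1, which gives 10000 nM, so a measurable number remains possible. The estimated change is a number no higher from compound 2 to compound 3 (the limit leaves the size open). The expected value for compound 3 is 100000 nM, with an estimated range of 30000 nM to 200000 nM.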

Compound 3, concentration for 50% growth inhibition: 10000 nM
The estimate for compound 3 lay 10-fold (1.00 log units) above the measured number; measured number outside the range, below it.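

In this assay, replacing chloro with bromo on the 4-chlorophenyl gives an at least 10-fold lower number from compound 2 to compound 3 (1.00 log units; beyond the scatter), so in this pair a single halogen swap at this position separates a compound with a measurable number from one without. With the 4-bromophenyl held in place, dimethylamino in place of methoxy gives no change at the digits printed from compound 1 to compound 3 (within the scatter), so this pair shows no sign that the choice between those two groups matters. The value of compound 2 is a limit of the assay and not a number, so the true size of the first step stays open: the limit of > 100000 nM in this assay, at which 1 of the 3 values shown sits.

The compounds shown leave open whether the same swap would matter with methoxy in place of dimethylamino. They also leave open whether iodo, fluoro or methyl at this position would behave like bromo or like chloro.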